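This account rests on a few compounds, and the source may have more. Where it says the series, first, only, none or still open, it means among the compounds named here.

Three compounds share one core and differ only in the group carried on a saturated ring carbon. Compound 1 `COc1ccc([C@H]2CC(c3cc4ccccc4oc3=O)=NN2c2ccccc2)cc1` was tested in a functional assay on the whole organism (strain albino) for inhibition, with Rattus norvegicus as the target, read by paw edema, with stated times of 1 h and 4 h, at a dose of 200 mg/kg by the oral route (a higher number here means more inhibition at the dose given (going by the name of the read-out), a lower number less inhibition), where compound 1 gives 36.2%. Compound 2 `O=c1oc2ccccc2cc1C1=NN(c2ccccc2)[C@@H](/C=C/c2ccccc2)C1` gives 42.5%, and compound 3 `Cc1ccc([C@H]2CC(c3cc4ccccc4oc3=O)=NN2c2ccccc2)cc1` gives 38%. Of the three numbers, that of compound 1 is the smallest, yet every gap is small: a number 6.3 percentage points higher from compound 1 to compound 2 (within the scatter), and a number 1.8 percentage points higher from compound 1 to compound 3 (within the scatter). In the same way, a number 4.5 percentage points lower from compound 2 to compound 3 (within the scatter). Compound 4 `COc1cccc([C@H]2CC(c3cc4ccccc4oc3=O)=NN2c2ccccc2)c1` has not yet been measured. It differs from compound 1 in one way: 3-methoxyphenyl in place of 4-methoxyphenyl on a saturated ring carbon. Among the measured compounds shown here, no measured step swaps 4-methoxyphenyl for 3-methoxyphenyl, so the only guide is that every change seen so far at this saturated ring carbon, whether a number 6.3 percentage points higher from compound 1 to compound 2 (within the scatter) or a number 1.8 percentage points higher from compound 1 to compound 3 (within the scatter), stayed within the scatter. For compound 4 the expected step is therefore a number 1.8 percentage points higher from compound 1 to compound 4 (within the scatter), nothing beyond the scatter. Compound 4 is estimated to give 38%, with a range from 28% to 48%.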

Compound 4, a percentage reported as inhibition, in the whole organism at one dose (the size of the read-out at that dose, not a potency): 61.5%
Beside the measured number, compound 4's estimate is 23.5 percentage points below it; the measured number lies above the stated range.
By their numbers in this assay, from the lowest: compounds 1, 3 and 2 (each within the scatter of the next); then compound 4.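

In this assay, among the compounds shown here, this saturated ring carbon turns out to be sensitive to its group: with the same atoms joined differently, 3-methoxyphenyl in place of 4-methoxyphenyl brings a number 25.3 percentage points higher from compound 1 to compound 4 (beyond the scatter) as the first step here to leave the scatter. The 3-methoxyphenyl group also stands clear of the other two groups, with a number 23.5 percentage points higher from compound 3 to compound 4 (beyond the scatter) and a number 19 percentage points higher from compound 2 to compound 4 (beyond the scatter) as well, while compounds 1, 2 and 3 remain within the scatter of each other. Nothing measured here bears on why rejoining the same atoms changes the number so much.

It remains open whether the methoxy group itself is needed, since no compound shown carries a chlorine atom, a hydroxyl or an amine in its place on that phenyl ring. A single oral dose also leaves open whether the gap would hold at other doses.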